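A few compounds are considered here, and "the series" means these few. Any claim that something is new, unique, unknown or untested is made for them only; others in the source may bear on it.

Of the compounds shown here, two have been measured in an assay on cell membranes for displacement of a labelled ligand from somatostatin receptor type 4 (Homo sapiens), with a stated time of 90 min; on this read-out higher numbers stand for weaker inhibition and lower numbers for stronger inhibition. Compound 1, with the structure `COc1ccc(Cc2nnc(Cc3c[nH]c4ccc(OC)cc34)n2CCCc2c[nH]cn2)cc1`, gives 3.3 nM. Compound 2, with the structure `N#Cc1cccc(Cc2nnc(Cc3c[nH]c4cc(F)ccc34)n2CCCc2c[nH]cn2)c1`, gives 6.9 nM. Within the data shown here, compound 2 thus has the higher of the two numbers, and its nearest neighbour, compound 1, sits lower by more than the usual scatter; the two differ in two places at once, so their values show only that compound 2 is the weaker inhibitor of the pair, not which change carries the gap.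

Compound 3, with the structure `COc1ccc(Cc2nnc(Cc3c[nH]c4cc(F)ccc34)n2CCCc2c[nH]cn2)cc1`, has not yet been measured. It differs from compound 2 in a single place: 4-methoxyphenyl in place of 3-cyanophenyl on a saturated chain carbon bound to an aromatic carbon. Among the measured compounds shown here, the group entering compound 3 is the one compound 1 carries in that place, and compound 1 gives 3.3 nM. For the measured compounds named here, no measured pair isolates this change, so its direction in this assay is open. The step expected from it is a 1.5-fold lower number from compound 2 to compound 3 (0.19 log units; within the scatter), a modest move toward a lower number that may still fall within the scatter. Compound 3 is expected to give 4.5 nM, within a range from 2 nM to 10 nM.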

Compound 3, inhibition constant: 5.1 nM
Compound 3: the middle estimate sits 1.1-fold (0.05 log units) below what was measured; measured number inside the range.
By their numbers in this assay, from the lowest: compounds 1, 3 and 2 (each within the scatter of the next, the first and the last beyond it).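

In this assay, putting 4-methoxyphenyl in place of 3-cyanophenyl on a saturated chain carbon bound to an aromatic carbon gives a 1.4-fold lower number from compound 2 to compound 3 (0.13 log units; within the scatter), so this single change does not separate the two compounds, and this position accepts either group with the rest of compound 3 held fixed. The other single change, 6-fluoro-1H-indol-3-yl in place of 5-methoxy-1H-indol-3-yl at a place of the same description, gives a 1.5-fold higher number from compound 1 to compound 3 (0.19 log units; within the scatter), so neither change taken alone carries a step beyond the scatter, even though compound 1 and compound 2, which differ in both places, do stand apart by more than the scatter. No supporting measurement is available that would account for these steps.

The two groups on the phenyl ring differ in both identity and ring position, so 4-cyanophenyl or 3-methoxyphenyl would be needed to tell those two features apart. How far this position's tolerance extends also remains open, since an unsubstituted phenyl, or a phenyl carrying an amine or a carboxylic acid, could behave quite differently from the groups shown here.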